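Aryl swap on a triazole nitrogen near the assay ceiling

The compounds below may be only part of what the source reports. "The series", "measured", "known", "first", "only" and "open" are said of these compounds alone.

Compound 3 `N#CC1=C(N)Oc2c(N)cc3nc4ccccc4nc3c2C12C(=O)N(Cc1cnnn1-c1ccc(Cl)cc1)c1ccccc12` sits at the upper limit of a functional assay on HepG2 cells (Homo sapiens) for antiproliferative activity, read by MTT assay, with a stated time of 48 h; on this read-out lower numbers stand for stronger inhibition and higher numbers for weaker inhibition: in this assay compound 3 gives > 50000 nM, which is a limit and not a number. Within the data shown here, compound 1 `N#CC1=C(N)Oc2c(c3nc4ccccc4nc3c3ccccc23)C12C(=O)N(Cc1cnnn1-c1ccc(S(N)(=O)=O)cc1)c1ccccc12` is the only member of the set with a measured number; in this assay compound 1 gives 42200 nM. Compound 2 `Cc1cc(C)cc(-n2nncc2CN2C(=O)C3(C(C#N)=C(N)Oc4c3c3nc5ccccc5nc3c3ccccc43)c3ccccc32)c1` also reaches the ceiling; in this assay compound 2 gives > 50000 nM, again a limit. Among the measured compounds shown here, the one measured step, an at least 1.1-fold higher number from compound 1 to compound 2 (0.07 log units; that floor lies within the scatter), changes the aryl group on the triazole nitrogen and ends at the limit, as the limit of > 50000 nM in this assay, at which 2 of the 3 values shown sit, records. Compound 4 `COc1ccccc1-n1nncc1CN1C(=O)C2(C(C#N)=C(N)Oc3c(N)cc4nc5ccccc5nc4c32)c2ccccc21` differs from compound 3 by 2-methoxyphenyl in place of 4-chlorophenyl on an aromatic nitrogen. For the measured compounds named here, since the only comparable aryl swap did not move a compound away from the weak end, compound 4 is expected to stay at or near the ceiling as well, with the step of a number no higher from compound 3 to compound 4 (the limit leaves the size open) estimated as none beyond the scatter. For compound 4 the estimate in this assay is 50000 nM, ranging from 25000 nM to 100000 nM.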

Compound 4, half-maximal inhibitory concentration: > 50000 nM
Compound 4 ended at the assay's limit; the forecaster's own chance of this, stated with the estimate: 60%; the middle value sits exactly at the limit.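

In this assay, among these compounds, compound 3 and compound 4 both end at a limit and not at a number, so no step between them can be read, and the set stays crowded at the ceiling: the limit of > 50000 nM in this assay, at which 3 of the 4 values shown sit. The compounds shown leave open how far 2-methoxyphenyl and 4-chlorophenyl differ on this aromatic nitrogen.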